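Group change on the aromatic oxygen: working notes

A few compounds are considered here, and "the series" means these few. Any claim that something is new, unique, unknown or untested is made for them only; others in the source may bear on it.

Values from an ADME assay on the whole organism (strain FVB) for pharmacokinetics, with Mus musculus as the target, read by LC-MS, at a dose of 30 mg/kg by the oral route (a lower number here means less compound in the circulation, a higher number more compound in the circulation at the dose given), so far are these.
- compound 1 `c1cc([C@H]2CC[C@]3(CC2)OOC2(O3)C3CC4CC(C3)CC2C4)ccc1OC1CCNCC1` gives 810 nM
- compound 2 `c1cc([C@H]2CC[C@]3(CC2)OOC2(O3)C3CC4CC(C3)CC2C4)ccc1OCC1CCNCC1` gives 465 nM

Among the compounds with values here, the only measured step is a 1.7-fold lower number from compound 1 to compound 2 (0.24 log units; within the scatter) and so compound 2 stands level with compound 1 on these numbers. Compound 3 `N[C@H]1CC[C@@H](Oc2ccc([C@H]3CC[C@]4(CC3)OOC3(O4)C4CC5CC(C4)CC3C5)cc2)CC1` differs from compound 2 by 4-aminocyclohexyl in place of (piperidin-4-yl)methyl on an oxygen on an aromatic ring and the shared core stays as it is. The two have the same atoms, joined differently, and the entering ring is of carbon only. Within the data shown here, the measured step falls at the same place, on the oxygen on the aromatic ring, but no measured compound carries 4-aminocyclohexyl, so it gives only a loose guide. No step beyond the scatter is expected in this assay here. The expected step is a 1.1-fold higher number from compound 2 to compound 3 (0.03 log units; within the scatter) as an estimate only. For compound 3 the estimated value is 500 nM with an expected range from 170 nM to 1400 nM at this stage.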

Compound 3, maximal plasma concentration: 1170 nM
The estimate for compound 3 lay 2.3-fold (0.37 log units) below the measured number; low and high end bracket the measured number.
By their numbers in this assay, from the lowest: compounds 2, 1 and 3 (each within the scatter of the next, the first and the last beyond it).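

In this assay, the oxygen on the aromatic ring now shows a step beyond the scatter, with 4-aminocyclohexyl in place of (piperidin-4-yl)methyl (a 2.5-fold higher number from compound 2 to compound 3 (0.40 log units; beyond the scatter)). Within the data shown here, with 4-aminocyclohexyl in place of piperidin-4-yl, the step stays within the scatter (a 1.4-fold higher number from compound 1 to compound 3 (0.16 log units; within the scatter)), so only the pair of compound 2 and compound 3 separates on these numbers, and the change of group at this oxygen is not neutral for every pair. Nothing on hand bears on the origin of the step.

Still open, as far as these compounds go, is whether the ring of carbon only or the place of the nitrogen carries the step, and what part the two defined stereocentres of 4-aminocyclohexyl play. Also open, from the compounds shown here alone, is how a 4-hydroxycyclohexyl group on the same oxygen would read.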